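Working notes: cytotoxicity of compounds 1 to 4

The source may hold more compounds than are shown below. What is called first, only, known or untested is meant among the compounds shown, and "the series" means these compounds.

Measured so far:
compound 1 `O=c1cc(NCc2ccc(F)cc2)sc2c([N+](=O)[O-])cc(C(F)(F)F)cc12` — > 64 ug/mL
compound 2 `O=c1nc(NCc2ccccc2)oc2c([N+](=O)[O-])cc(C(F)(F)F)cc12` — 25.4 ug/mL
compound 3 `O=c1nc(Nc2ccccc2)oc2c([N+](=O)[O-])cc(C(F)(F)F)cc12` — 37.9 ug/mL

In an ADME assay on Vero cells (Chlorocebus sabaeus) for cytotoxicity, read by MTT assay, with a stated time of 48 h (on this read-out higher numbers stand for weaker inhibition and lower numbers for stronger inhibition), compound 1 reaches only the limit > 64 ug/mL, which is a limit of the assay and not a number. Compound 2 gives 25.4 ug/mL in this assay. Compound 3 gives 37.9 ug/mL in this assay. Within the data shown here, the one counted step, a 1.5-fold higher number from compound 2 to compound 3 (0.17 log units; within the scatter), is within the scatter, so compound 2 and compound 3 are read as alike.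

Compound 4 `O=c1cc(NCC2CCCCC2)sc2c([N+](=O)[O-])cc(C(F)(F)F)cc12` differs from compound 1 in one place: cyclohexyl in place of 4-fluorophenyl on a saturated chain carbon bound to a nitrogen on an aromatic ring. Among the measured compounds shown here, no measured step touches this change; the step of a 1.5-fold higher number from compound 2 to compound 3 (0.17 log units; within the scatter) concerns another nitrogen on another core and is in any case within the scatter. The only bearing comes from the limit of > 64 ug/mL in this assay, at which 1 of the 3 values shown sits, where compound 1 already sits. Compound 4 is therefore expected to stay near that limit, around 70 ug/mL, between 30 ug/mL and 130 ug/mL. That estimate means a step that the limit leaves unreadable from compound 1 to compound 4, not expected to go beyond the scatter, and it is quite likely that only a limit will again be reported.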

Compound 4, half-maximal inhibitory concentration: > 64 ug/mL
Compound 4: a limit, no number (the forecaster's own chance of this, stated with the estimate: 60%); the middle value is on the limit's open side.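

In this assay compound 4 gives > 64 ug/mL, a limit of the assay and not a number. No step from compound 1 to compound 4 can be read, because both values are limits: the limit of > 64 ug/mL in this assay, at which 2 of the 4 values shown sit. The compounds shown leave open whether cyclohexyl in place of 4-fluorophenyl shifts the read-out at all.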